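The source may hold more compounds than are shown below. What is called first, only, known or untested is meant among the compounds shown, and "the series" means these compounds.

Within the data shown here, compound 1 `Cc1ccc(Cl)cc1Nc1nc(C(F)(F)F)ccc1CNC(=O)C(C)c1ccc(NS(C)(=O)=O)c(F)c1` gives 14 nM in a functional assay on CHO-K1 cells for antagonist activity at transient receptor potential cation channel subfamily V member 1 (Homo sapiens), read by FLIPR (on this read-out lower numbers stand for stronger inhibition and higher numbers for weaker inhibition), the highest of the two numbers measured so far; compound 2 `CC(C(=O)NCc1ccc(C(F)(F)F)nc1N(C)c1ccccc1)c1ccc(NS(C)(=O)=O)c(F)c1` gives 0.9 nM. Compound 3 `CC(=O)OC1CCN(c2nc(C(F)(F)F)ccc2CNC(=O)C(C)c2ccc(NS(C)(=O)=O)c(F)c2)CC1` differs from compound 1 in one place: 4-acetoxypiperidin-1-yl in place of (5-chloro-2-methylphenyl)amino on an aromatic carbon. Among the measured compounds shown here, the one step available at this position, a 16-fold lower number from compound 1 to compound 2 (1.19 log units; beyond the scatter), shows that exchanging the (5-chloro-2-methylphenyl)amino group can move the number a long way, though 4-acetoxypiperidin-1-yl is unlike methyl(phenyl)amino and its direct step is untested. Compound 3 is therefore expected to show a smaller step in the same direction, a 2.8-fold lower number from compound 1 to compound 3 (0.45 log units; beyond the scatter). Compound 3 is estimated at 5 nM, within 1.5 nM to 25 nM.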

Compound 3, inhibition constant: 4 nM
Compound 3: middle estimate off by 1.3-fold (0.10 log units), on the high side; low and high end bracket the measured number.
By their numbers in this assay, from the lowest: compound 2; then compound 3; then compound 1.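

In this assay, the aromatic carbon next to the ring nitrogen also tolerates a non-aromatic ring: 4-acetoxypiperidin-1-yl gives a 3.5-fold lower number from compound 1 to compound 3 (0.54 log units; beyond the scatter), so an aromatic ring in this group is not required for a number lower than that of compound 1. Methyl(phenyl)amino still gives the lowest number of the three, with a 4.4-fold higher number from compound 2 to compound 3 (0.65 log units; beyond the scatter). No measurement at hand explains either step. As far as these compounds go, the contribution of the acetoxy group remains open, and 4-hydroxypiperidin-1-yl or morpholin-4-yl at this position would test it.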